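The source may report more compounds than this note shows. Statements on the series, on what has been measured and on what is new or still open speak of the compounds shown alone.

Compounds 1, 2 and 3 share a single core and differ only in their peripheral groups. Compound 1 `Cc1cc(F)ccc1/C=C(/SCc1ccc(F)cc1)C(=O)c1ccc(Br)cc1` gives 10000 nM in a functional assay on DU-145 cells (Homo sapiens) for inhibition, read by trypan blue exclusion, with a stated time of 96 h; on this read-out higher numbers stand for weaker inhibition of growth and lower numbers for stronger inhibition of growth. Compound 2 `CSc1ccc(/C=C(\C(=O)c2ccc(Br)cc2)S(=O)(=O)c2ccc(C)cc2)cc1` gives 1000 nM in this assay, and compound 3 `CSc1ccc(/C=C(\C(=O)c2ccc(Br)cc2)S(=O)(=O)Cc2ccc(C)cc2)cc1` gives 10000 nM. Compound 2 therefore stands at the lowest of the three numbers, each of the other two lying higher by an amount beyond the scatter. Within the data shown here, the single step measured between compounds that differ in one place is a 10-fold higher number from compound 2 to compound 3 (1.00 log units; beyond the scatter).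

Compound 4 `Cc1ccc(S(=O)(=O)/C(=C/c2ccc(N(C)C)cc2)C(=O)c2ccc(Br)cc2)cc1` departs from compound 2 at another site: dimethylamino in place of methylsulfanyl on an aromatic carbon. Among the measured compounds shown here, no measured pair shows a dimethylamino in place of a methylsulfanyl on an aromatic carbon. For the measured compounds named here, the only step at hand, that from compound 2 to compound 3, concerns the group on the sulfonyl sulfur, not the ring bearing the methylsulfanyl, and so does not bear on this change. In the absence of any comparable step, the change is expected to leave the number where compound 2 sits, with no step beyond the scatter. The expected step is no change at the digits printed from compound 2 to compound 4 (within the scatter). Compound 4 is accordingly estimated at 1000 nM in this assay, within a range from 300 nM to 3000 nM.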

Compound 4, concentration for 50% growth inhibition: 50000 nM
For compound 4 the middle estimate is 50-fold (1.70 log units) below the measured one, and the stated range ends below it.
By their numbers in this assay, from the lowest: compound 2; then compounds 1 and 3 (each within the scatter of the next); then compound 4.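

In this assay, the group on the aromatic carbon para to a large group proves to be a sensitive position: the step from 4-(methylsulfanyl)phenyl to 4-(dimethylamino)phenyl is a 50-fold higher number from compound 2 to compound 4 (1.70 log units; beyond the scatter) and marks clearly weaker inhibition of growth. Together with a 10-fold higher number from compound 2 to compound 3 (1.00 log units; beyond the scatter) at the sulfonyl sulfur, this gives two separate sites at which a single change from compound 2 raises the number beyond the scatter, and the new step comes from an exchange that leaves the listed hydrogen-bond donor and acceptor counts and the net charge unchanged. Nothing available here accounts for the size of this step.

The compounds shown leave open whether the result follows from the nitrogen or from its two methyl groups, which a primary amine, a methoxy group or a simple methyl at this position could help separate. They also leave open whether dimethylamino would give a step of similar size when the 4-methylbenzyl group of compound 3 sits on the sulfonyl sulfur.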